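From Amide to Urea on a Shared Core

The source may hold more compounds than are shown below. What is called first, only, known or untested is meant among the compounds shown, and "the series" means these compounds.

Compound 1, `COc1cc(-c2nn(-c3cccc(NC(=O)c4cccc(C(F)(F)F)c4)c3)cc2-c2ccncc2)ccc1Cl`, was tested in a functional assay on SN12C cells (Homo sapiens) for inhibition, read by sulforhodamine B assay, with a stated time of 48 h; a higher number here means a weaker inhibitor of growth, a lower number a stronger inhibitor of growth. In this assay compound 1 gives > 50000 nM, which is a limit of the assay rather than a measured number. Within the data shown here, it is the single value among the three that sits at the limit of > 50000 nM in this assay, at which 1 of the 3 values shown sits. Two urea compounds built on a slightly different core were also measured: compound 2, `O=C(Nc1cccc(-n2cc(-c3ccncc3)c(-c3ccc(Cl)c(O)c3)n2)c1)Nc1cc(C(F)(F)F)cc(C(F)(F)F)c1`, gives 5450 nM, and compound 3, `O=C(Nc1cccc(-n2cc(-c3ccncc3)c(-c3ccc(Cl)c(O)c3)n2)c1)Nc1ccc(Cl)c(C(F)(F)F)c1`, gives 17100 nM. Compound 4, `COc1cc(-c2nn(-c3cccc(NC(=O)Nc4ccc(Cl)c(Cl)c4)c3)cc2-c2ccncc2)ccc1Cl`, awaits measurement. It differs from compound 1 by (3,4-dichlorophenyl)amino in place of 3-(trifluoromethyl)phenyl on a carbonyl carbon. Among the measured compounds shown here, no measured pair shows this exact change. The ureas compound 2 and compound 3 at least give countable numbers. Compound 4 is therefore expected near 15000 nM, within 4000 nM to 50000 nM, the step of an at least 3.3-fold lower number from compound 1 to compound 4 (0.52 log units; beyond the scatter) expected to be beyond the scatter.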

Compound 4, concentration for total growth inhibition: > 50000 nM
Compound 4: only a limit was reported (the forecaster's own chance of this, stated with the estimate: 30%); middle value at least 3.3-fold (0.52 log units) away from the limit.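

Among these compounds, compound 1 and compound 4 each give only a limit of the assay, not a number, so no step between them can be read. As far as these compounds go, whether swapping 3-(trifluoromethyl)phenyl for (3,4-dichlorophenyl)amino changes growth inhibition on this core remains open.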